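The source may hold more compounds than are shown below. What is called first, only, known or untested is meant among the compounds shown, and "the series" means these compounds.

Measured in a functional assay on the whole organism (strain Sprague-Dawley) for inhibition, with Rattus norvegicus as the target, with a stated time of 10 min; on this read-out lower numbers stand for an effect already at smaller amounts and higher numbers for an effect only at larger amounts of compound:
- compound 1 `CCOC(=O)c1cnc(-c2ccccc2O)[nH]c1=O`: 5 mg/kg
- compound 2 `CCOC(=O)c1cnc(-c2ccccc2OC)[nH]c1=O`: 10 mg/kg

Compound 2 gives 10 mg/kg and stands within the usual scatter of compound 1, so these two numbers do not separate the pair. The next compound, compound 3 `CCOC(=O)c1cnc(-c2ccccc2OCC)[nH]c1=O`, differs from compound 2 by one small change: methyl in place of hydrogen on a saturated chain carbon bound to an oxygen on an aromatic ring. In words, methyl takes the place of hydrogen on a saturated chain carbon bound to an oxygen on an aromatic ring, which turns methoxy into ethoxy.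

Among the compounds with values here, only one measured step bears on this: a 2.0-fold higher number from compound 1 to compound 2 (0.30 log units; within the scatter). There, too, a methyl was added, though directly on the oxygen and not on a chain carbon, so it is a related change and not the same one. Within the data shown here, a single step is thin evidence, and the data hold no example of the change to ethoxy. Since a 2.0-fold higher number from compound 1 to compound 2 (0.30 log units; within the scatter) stayed so small, no shift beyond the scatter is expected in this assay. The expected step is no change at the digits printed from compound 2 to compound 3 (within the scatter). For compound 3 the estimated value is 10 mg/kg, with an expected range from 3 mg/kg to 30 mg/kg.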

Compound 3, dose for 50% inhibition: 2 mg/kg
Compound 3: middle estimate off by 5.0-fold (0.70 log units), on the high side, outside the stated range (below it).
By their numbers in this assay, from the lowest: compound 3; then compounds 1 and 2 (each within the scatter of the next).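

In this assay, the group on the oxygen on the aromatic ring now has a readable effect: methyl in place of hydrogen on the saturated chain carbon, which turns methoxy into ethoxy, gives a 5.0-fold lower number from compound 2 to compound 3 (0.70 log units; beyond the scatter) and moves the result beyond the usual scatter. Compound 3 also separates from the compound with hydrogen on that oxygen, since ethyl in place of that hydrogen gives a 2.5-fold lower number from compound 1 to compound 3 (0.40 log units; beyond the scatter), whereas compound 1 and compound 2 could not be told apart. So in this short series, the ethoxy group is the one change that stands out, with compound 3 giving the lowest number of the three, although the data offer no measurement that would explain why a single added methyl matters here.

Three compounds cannot show whether this effect continues with a longer chain on the oxygen, such as propoxy or butoxy, or whether it stops at ethoxy. Going by these compounds, it also remains open how a branched group such as isopropoxy, or a chain ending in an amine or a carboxylic acid, would compare with ethoxy on the same core.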